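A pyridinyl swap in a series at the limit

This account rests on a few compounds, and the source may have more. Where it says the series, first, only, none or still open, it means among the compounds named here.

Of the compounds shown here, three have been tested in an ADME assay on cells (Homo sapiens) for cytotoxicity, read by resazurin assay, with a stated time of 5 days; on this read-out higher numbers stand for lower toxicity in this test and lower numbers for higher toxicity in this test. Compound 1 (`COc1ccc(-c2nc(C(F)(F)S(=O)(=O)c3cccc(Cl)c3)nc3ccsc23)cn1`) gives > 50000 nM, which is a limit and not a number. Compound 2 (`COc1ccc(-c2nc(COc3cccc(Cl)c3)nc3ccsc23)cn1`) gives > 50000 nM, again a limit. Compound 3 (`O=S(=O)(Cc1nc(-c2ccncc2)c2sccc2n1)c1cccc(Cl)c1`) gives > 50000 nM, also a limit and not an exact value. The whole set is summed up by the limit of > 50000 nM in this assay, at which 3 of the 3 values shown sit.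

Compound 4 (`O=S(=O)(Cc1nc(-c2cccnc2)c2sccc2n1)c1cccc(Cl)c1`) keeps the frame of compound 3 but carries pyridin-3-yl in place of pyridin-4-yl on an aromatic carbon. Among the measured compounds shown here, no two tested compounds differ in one place only, so no measured step can guide the expectation. No shift beyond the usual scatter is expected, and the estimated change is a number no higher from compound 3 to compound 4 (the limit leaves the size open). This expectation rests on compound 3, which reads > 50000 nM, a limit. Compound 4 is expected at 50000 nM, with an estimated range of 25000 nM to 100000 nM, and the assay will probably report only a limit again.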

Compound 4, half-maximal cytotoxic concentration: > 50000 nM
Compound 4: a limit, no number; the forecaster's own chance of this, stated with the estimate: 85%; the middle value lies on the limit itself.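

In this assay compound 3 gives > 50000 nM, a limit. Compound 4 gives > 50000 nM, also a limit, so no step can be read between compound 3 and compound 4. The compounds shown leave open where any of them would give an exact value: the limit of > 50000 nM in this assay, at which 4 of the 4 values shown sit.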